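The source may report more compounds than this note shows. Statements on the series, on what has been measured and on what is new or still open speak of the compounds shown alone.

Compound 1 `Cc1ccc(NC(=O)c2cccc(C(F)(F)F)c2)cc1OC1CCN(C(=O)c2cccnc2)CC1` — in an ADME assay on BaF3 cells (Mus musculus) for antiproliferative activity (a higher number here means a weaker inhibitor of growth, a lower number a stronger inhibitor of growth), compound 1 gives > 10000 nM, which is a limit of the assay and not a number.
Compound 2 `C=CC(=O)N1CCC(Oc2cc(NC(=O)c3cccc(C(F)(F)F)c3)ccc2C)CC1` — in this assay compound 2 gives > 10000 nM, again a limit rather than a number.
Compound 3 `Cc1ccc(NC(=O)c2cc(F)cc(C(F)(F)F)c2)cc1OC1CCN(C(=O)c2cccnc2)CC1` — in this assay compound 3 gives > 10000 nM, again a limit rather than a number.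

Compound 3 thus stands where the whole set stands: the limit of > 10000 nM in this assay, at which 3 of the 3 values shown sit. Going by the values given here, the two measured steps, a step that the two limits leave unreadable from compound 1 to compound 2 and a step that the two limits leave unreadable from compound 1 to compound 3, both run between limits and have no readable size; they show only that neither change brought growth inhibition into the measurable window. Among the compounds with values here, of these, the step from compound 1 to compound 3 also alters the aryl group on the amide carbonyl, but without a readable size it gives no precedent for direction.

Compound 4 `Cc1ccc(NC(=O)c2cnc3ccccc3c2)cc1OC1CCN(C(=O)c2cccnc2)CC1` differs from compound 3 by quinolin-3-yl in place of 3-fluoro-5-(trifluoromethyl)phenyl on a carbonyl carbon. With nothing readable to build on, the step from compound 3 to compound 4 is estimated as a number no higher from compound 3 to compound 4 (the limit leaves the size open), with a strong chance that only a limit is returned. Compound 4 is therefore expected to give 10000 nM, in a range from 2000 nM to 50000 nM.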

Compound 4, concentration for 50% growth inhibition: > 10000 nM
Compound 4: a limit, no number; the forecaster's own chance of this, stated with the estimate: 70%; the middle value lies on the limit itself.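

In this assay compound 4 gives > 10000 nM as a limit and not a number, so its steps from compound 1 and compound 3 cannot be read. The compounds shown leave open whether any change to these groups brings growth inhibition into the measurable window.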